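Pyridinyl piperazine variant of an aminothiophene ketone

The compounds below may be only part of what the source reports. "The series", "measured", "known", "first", "only" and "open" are said of these compounds alone.

Of the compounds shown here, three sharing one core have been measured. Compound 1 `Nc1scc(CN2CCN(C3CCCCC3)CC2)c1C(=O)c1ccc(Cl)cc1` carries a cyclohexyl group on an amine nitrogen in a ring; in an assay on CHO cells for displacement of a labelled ligand from adenosine receptor A1 (Homo sapiens) (on this read-out lower numbers stand for tighter binding and higher numbers for weaker binding), compound 1 gives 1.1 nM. Compound 2 `Nc1scc(CN2CCN(c3ccc(Cl)cc3)CC2)c1C(=O)c1ccc(Cl)cc1` bears a 4-chlorophenyl group at that position, and in this assay compound 2 gives 1.1 nM. Compound 3 `Cc1ccc(N2CCN(Cc3csc(N)c3C(=O)c3ccc(Cl)cc3)CC2)cc1` bears a 4-methylphenyl group there; in this assay compound 3 gives 1 nM. The three numbers sit together: no change at the digits printed from compound 1 to compound 2 (within the scatter), a 1.1-fold lower number from compound 1 to compound 3 (0.04 log units; within the scatter) and a 1.1-fold lower number from compound 2 to compound 3 (0.04 log units; within the scatter) all fall within the scatter, so compound 3 cannot be set apart from compound 1 or compound 2 on these numbers.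

Compound 4 `Nc1scc(CN2CCN(c3ccccn3)CC2)c1C(=O)c1ccc(Cl)cc1` has not been measured. It differs from compound 3 in one place: pyridin-2-yl in place of 4-methylphenyl on an amine nitrogen in a ring. Going by the values given here, the steps that bear on this change are those that swap the group on this ring nitrogen, no change at the digits printed from compound 1 to compound 2 (within the scatter) and a 1.1-fold lower number from compound 1 to compound 3 (0.04 log units; within the scatter), and both stayed within the scatter even though cyclohexyl, 4-chlorophenyl and 4-methylphenyl are quite different groups. Among the compounds with values here, no measured step introduces a ring nitrogen at this position, so the pyridin-2-yl group is untested here. The account therefore expects no step beyond the scatter, a 1.5-fold higher number from compound 3 to compound 4 (0.18 log units; within the scatter). Compound 4 is expected to give about 1.5 nM in this assay, within an estimated range from 0.5 nM to 5 nM.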

Compound 4, dissociation constant: 1.2 nM
The estimate for compound 4 lay 1.3-fold (0.10 log units) above the measured number; the measured number falls inside the stated range.
By their numbers in this assay, from the lowest: compounds 3, 1, 2 and 4 (each within the scatter of the next).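

With pyridin-2-yl on this amine nitrogen in a ring, a hetero atom enters the aromatic ring at this position for the first time among these compounds, along with a hydrogen-bond acceptor that 4-methylphenyl lacks. Even so, all three new steps in this assay stay within the scatter (a 1.2-fold higher number from compound 3 to compound 4 (0.08 log units; within the scatter); a 1.1-fold higher number from compound 2 to compound 4 (0.04 log units; within the scatter); a 1.1-fold higher number from compound 1 to compound 4 (0.04 log units; within the scatter)). The four compounds therefore cannot be told apart on this read-out, and the tolerance seen earlier across cyclohexyl, 4-chlorophenyl and 4-methylphenyl now extends to an aromatic ring with a ring nitrogen, although nothing available here explains this result.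

The compounds shown leave open whether this position would hold the same numbers with a group of a different kind, such as a carboxylic acid on a longer chain or a free primary amine, since every group here is a single six-membered ring. They also leave open whether the pyridin-2-yl group would behave the same way if the 4-chlorophenyl ketone of the shared core were replaced by another group.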